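Methyl for chloro at the weak end of the series

A few compounds are considered here, and "the series" means these few. Any claim that something is new, unique, unknown or untested is made for them only; others in the source may bear on it.

In a functional assay on PC-3 cells (Homo sapiens) for cytotoxicity, read by MTT assay, with a stated time of 72 h (on this read-out lower numbers stand for stronger inhibition and higher numbers for weaker inhibition), compound 1 (`CNC(=O)c1cc(Oc2ccc(NC(=O)c3cc(-c4ccc(Cl)cc4)ncn3)cc2F)ccn1`) gives > 100000 nM, which is a limit and not a number. Compound 2 (`CNC(=O)c1cc(Oc2ccc(NC(=O)c3cc(-c4ccc(Cl)cc4)ncn3)cc2)ccn1`) gives > 100000 nM, also a limit. Compound 3 (`CNC(=O)c1cc(Oc2ccc(NC(=O)c3nccc(-c4ccc(OC)cc4)n3)cc2)ccn1`) gives a measured number, 14200 nM. The standing of compound 1 is therefore known only as the limit of > 100000 nM in this assay, at which 2 of the 3 values shown sit.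

Compound 4 (`CNC(=O)c1cc(Oc2ccc(NC(=O)c3cc(-c4ccc(C)cc4)ncn3)cc2F)ccn1`) keeps the core of compound 1 and carries methyl in place of chloro on an aromatic carbon, para to a large group: methyl in place of chloro on an aromatic carbon. For the measured compounds named here, the only step measured between close neighbours is a step that the two limits leave unreadable from compound 1 to compound 2. Its size cannot be read, and it concerns a different place in the structure, so it sets no size for this change. Compound 3 differs in more than one place and offers no direct guide.

A large gain in this assay is not expected, and compound 4 will probably stay weak, possibly reading as a limit again. The expected step is small and is estimated as an at least 1.6-fold lower number from compound 1 to compound 4 (0.22 log units; that floor lies within the scatter). Compound 4 is estimated at 60000 nM, with an expected range of 15000 nM to 100000 nM.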

Compound 4, half-maximal inhibitory concentration: 40200 nM
The estimate for compound 4 lay 1.5-fold (0.17 log units) above the measured number, within the range that was stated.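

Methyl in place of chloro gives an at least 2.4-fold lower number from compound 1 to compound 4 (0.39 log units; beyond the scatter) in this assay, the first step in the series that can be read at this position. That size is only a floor, as the value of compound 1 is a limit and not a number. Compound 4 thus gives a measured number on the core of compound 1, whereas both 4-chlorophenyl compounds read only as a limit: the limit of > 100000 nM in this assay, at which 2 of the 4 values shown sit.

Whether hydrogen in place of fluoro changes the number on the 4-methylphenyl compound stays open, as the one step shown for that change cannot be read. Also open, from the compounds shown here alone, is whether an amine, a carboxylic acid or a longer chain in place of methyl would lower the number further or return it to the limit.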